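This account rests on a few compounds, and the source may have more. Where it says the series, first, only, none or still open, it means among the compounds named here.

Measured in a functional assay on NCI-H1650 cells (Homo sapiens) for cytotoxicity, read by MTT assay, with a stated time of 72 h; on this read-out lower numbers stand for stronger inhibition and higher numbers for weaker inhibition:
- Compound 1 `COc1cc(/C=C2\CNC/C(=C\c3cc(OC)c(OC)c(OC)c3)C2=O)cc(OC)c1OC`: 4200 nM
- Compound 2 `COc1cc(/C=C2\CN(C(=O)CCC(=O)O)C/C(=C\c3cc(OC)c(OC)c(OC)c3)C2=O)cc(OC)c1OC`: > 60000 nM (a limit, not a number)

In this assay compound 2 stands only at a limit, > 60000 nM. Compound 3 `COc1cc(/C=C2\CN(C(=O)C(C)C)C/C(=C\c3cc(OC)c(OC)c(OC)c3)C2=O)cc(OC)c1OC` carries isopropyl in place of 2-carboxyethyl on a carbonyl carbon. Within the data shown here, one measured step bears on this change: an at least 14-fold higher number from compound 1 to compound 2 (1.15 log units; beyond the scatter), a large step that came with (2-carboxyethyl)carbonyl in place of hydrogen on an amine nitrogen in a ring. Among the measured compounds shown here, compound 3 keeps the carbonyl but loses the 2-carboxyethyl, and no measurement yet separates these two parts. A large move toward lower numbers is therefore expected, in the direction of compound 1 at 4200 nM. The expected size is an at least 20-fold lower number from compound 2 to compound 3 (1.30 log units; beyond the scatter). Compound 3 is estimated at 3000 nM, with an expected range of 500 nM to 20000 nM.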

Compound 3, half-maximal inhibitory concentration: 10800 nM
The estimate for compound 3 lay 3.6-fold (0.56 log units) below the measured number; low and high end bracket the measured number.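

In this assay, the group on the carbonyl matters a great deal, and isopropyl gives a far lower number than 2-carboxyethyl: an at least 5.5-fold lower number from compound 2 to compound 3 (0.74 log units; beyond the scatter). This step is only a bound, because compound 2 stands at a limit and not at a number: the limit of > 60000 nM in this assay, at which 1 of the 3 values shown sits. Compound 3 keeps the carbonyl on the amine nitrogen in a ring, so the carbonyl alone does not bring the large rise seen with compound 2, although it does come with a smaller rise: a 2.6-fold higher number from compound 1 to compound 3 (0.41 log units; beyond the scatter).

The groups 2-carboxyethyl and isopropyl differ both in the carboxylic acid and in the chain, and the compounds shown do not separate these two parts. As far as these compounds go, how a methyl ester of the same chain or a chain ending in an amine would read stays open.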